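This account rests on a few compounds, and the source may have more. Where it says the series, first, only, none or still open, it means among the compounds named here.

Measured so far:
Compound 1 `COc1ccccc1C1CC(c2cc3ccccc3o2)=NN1C(=O)c1ccncc1` — in an ADME assay on Vero cells (Chlorocebus sabaeus) for cytotoxicity, read by MTT assay, with a stated time of 72 h (a higher number here means a weaker inhibitor, a lower number a stronger inhibitor), compound 1 gives only a limit, > 202000 nM.
Compound 2 `CN(C)c1ccc(C2CC(c3cc4ccccc4o3)=NN2C(=O)c2ccncc2)cc1` — in this assay compound 2 likewise gives only a limit, > 210000 nM.

Compound 2 thus stands at the limit of > 210000 nM in this assay, at which 1 of the 2 values shown sits, a limit of this assay and not a number. Compound 1 stands at the limit of > 202000 nM in this assay, at which 1 of the 2 values shown sits, also a limit. Among the measured compounds shown here, the only measured step, a step that the two limits leave unreadable from compound 1 to compound 2, therefore has no readable size, and no direction can be drawn from it.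

Compound 3 `O=C(O)c1ccccc1C1CC(c2cc3ccccc3o2)=NN1C(=O)c1ccncc1` arises from compound 2 by the change (2-carboxyphenyl in place of 4-(dimethylamino)phenyl on a saturated ring carbon). For the measured compounds named here, no measured step resembles this change, and the one step available tells nothing of its size. Given that compound 2 sits at the limit of > 210000 nM in this assay, at which 1 of the 2 values shown sits, compound 3 is expected to reach the limit of this assay as well, with a step that the limit leaves unreadable from compound 2 to compound 3 expected to be no step beyond the scatter. Compound 3 is accordingly estimated at 250000 nM, within 100000 nM to 1000000 nM, most probably again reported only as a limit.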

Compound 3, half-maximal inhibitory concentration: > 170000 nM
Compound 3: a limit, no number (the forecaster's own chance of this, stated with the estimate: 85%); the middle value is on the limit's open side.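

In this assay compound 3 gives > 170000 nM, a limit and not a number. Among the compounds shown here, compound 1, compound 2 and compound 3 all stand at limits, so no step among them can be read. The compounds shown leave open whether changing the group on the saturated ring carbon alters the read-out in this assay at all.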